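Testing an Acetyl Group on the Pyrazole Nitrogen

This account rests on a few compounds, and the source may have more. Where it says the series, first, only, none or still open, it means among the compounds named here.

Two compounds sharing one core have so far been examined in a functional assay on MV4-11 cells (Homo sapiens) for antiproliferative activity, with a stated time of 6 days, tested at 6.25 uM; a lower number here means a weaker effect, a higher number a stronger effect of the compound at the concentration tested. Compound 1 `CNC(=O)N1CCCc2ccc(NC(=O)c3cccc(-c4ccn(C)n4)c3)cc21` gives 99.5% in this assay. Going by the values given here, compound 2 `CNC(=O)N1CCCc2ccc(NC(=O)c3cccc(-c4cn[nH]c4)c3)cc21` gives 77.7% in this assay, the lower of the two numbers, and the only measured step leads to it: a number 21.8 percentage points lower from compound 1 to compound 2 (beyond the scatter). Compound 2 thus stands at the bottom of the two values recorded.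

Compound 3 `CNC(=O)N1CCCc2ccc(NC(=O)c3cccc(-c4cnn(C(C)=O)c4)c3)cc21` differs from compound 2 in one place: acetyl in place of hydrogen on an aromatic nitrogen. Among the compounds with values here, the step from compound 1 to compound 2 is the only measured change that touches the same ring, and there a substituent on the ring nitrogen went together with the higher number. That step was of modest size, and it does not concern an acetyl group, so the bearing is loose. A modest rise for compound 3 is expected, wider than the scatter but not large, because a number 21.8 percentage points lower from compound 1 to compound 2 (beyond the scatter) points in that direction when read backwards. The estimate for compound 3 is therefore 87%, within a range from 68% to 99%, which corresponds to an expected step of a number 9.3 percentage points higher from compound 2 to compound 3 (within the scatter).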

Compound 3, a percentage reported as inhibition, at one concentration (the size of the read-out at that concentration, not a potency): 82%
Estimate against measurement, compound 3: 5 percentage points above, and the stated range covers the measured number.
By their numbers in this assay, from the lowest: compounds 2 and 3 (each within the scatter of the next); then compound 1.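

In this assay, an acetyl on the aromatic nitrogen of the 1H-pyrazol-4-yl group gives a read-out that cannot be told apart from that of the unsubstituted ring, a number 4.3 percentage points higher from compound 2 to compound 3 (within the scatter), so this nitrogen tolerates the added group, but the acetyl brings no measurable gain. A substituent on a ring nitrogen is therefore not enough on its own to reach the level of the methyl compound, and a real gap remains, a number 17.5 percentage points lower from compound 1 to compound 3 (beyond the scatter), although that step changes both the group on the nitrogen and the ring atom through which the pyrazole is attached. Nothing available here explains these numbers.

The compounds shown leave open which of those two differences accounts for the gap, and 1-methyl-1H-pyrazol-4-yl, with a methyl on the same nitrogen that bears the acetyl in compound 3, would pull them apart. Going by these compounds, it also remains open whether a longer chain such as propyl, or a chain ending in an amine, would behave like the acetyl on this nitrogen, and with only one tested concentration, none of these read-outs gives a potency.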